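Swapping nitro for methoxy on a P2X7 antagonist amide

The source may hold more compounds than are shown below. What is called first, only, known or untested is meant among the compounds shown, and "the series" means these compounds.

Of the compounds shown here, three sharing one core have been tested in an assay on HEK293 cells for antagonist activity at P2X purinoceptor 7 (Homo sapiens), read by fluorescence, with a stated time of 2 h; on this read-out lower numbers stand for stronger inhibition and higher numbers for weaker inhibition. Compound 1 `N#Cc1cccc(S(=O)(=O)Oc2ccc(-c3cncn3C3CCN(C(=O)c4ccc(Cl)c(C(F)(F)F)c4)CC3)cc2)c1` gives 73 nM, compound 2 `COc1ccc(C(=O)N2CCC(n3cncc3-c3ccc(OS(=O)(=O)c4cccc5cnccc45)cc3)CC2)cc1` gives 77 nM, and compound 3 `N#Cc1cccc(S(=O)(=O)Oc2ccc(-c3cncn3C3CCN(C(=O)c4ccc([N+](=O)[O-])cc4)CC3)cc2)c1` gives 45 nM. Compound 3 has the lowest number of the three, but its gap to compound 1 and to compound 2 is within the scatter, so no order among them can be claimed. Among the compounds with values here, the only single-point step measured so far, a 1.6-fold lower number from compound 1 to compound 3 (0.21 log units; within the scatter), is likewise within the scatter, which shows that changing the group on the carbonyl carbon left the number essentially where it was.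

Compound 4 `COc1ccc(C(=O)N2CCC(n3cncc3-c3ccc(OS(=O)(=O)c4cccc(C#N)c4)cc3)CC2)cc1` is the untested partner of compound 3. The difference is methoxy in place of nitro on an aromatic carbon. This change sits on the same ring that was varied in the step from compound 1 to compound 3, and that step moved the number very little. Within the data shown here, compound 2 also carries a methoxy group on this ring and gives a number close to that of compound 3, though its other end differs, so no step can be computed for that pair.

On this basis the expected step from compound 3 to compound 4 is a 1.3-fold higher number from compound 3 to compound 4 (0.12 log units; within the scatter), small and without clear direction. Compound 4 is therefore estimated at 60 nM, with a likely range from 25 nM to 140 nM.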

Compound 4, half-maximal inhibitory concentration: 312 nM
The estimate for compound 4 lay 5.2-fold (0.72 log units) below the measured number, outside the stated range (above it).
By their numbers in this assay, from the lowest: compounds 3, 1 and 2 (each within the scatter of the next); then compound 4.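

Within the data shown here, the nitro-to-methoxy swap shows that this position on the ring attached to the carbonyl is not as forgiving as the earlier compounds suggested: in this assay there is a 6.9-fold higher number from compound 3 to compound 4 (0.84 log units; beyond the scatter), a modest change but one beyond the scatter. With the 3-cyanophenyl group held constant on the sulfonyl sulfur, 4-methoxyphenyl also separates from 4-chloro-3-(trifluoromethyl)phenyl, with a 4.3-fold higher number from compound 1 to compound 4 (0.63 log units; beyond the scatter), whereas the 4-nitrophenyl and 4-chloro-3-(trifluoromethyl)phenyl groups could not be told apart. The methoxy group does not set the number alone, since keeping 4-methoxyphenyl and placing 3-cyanophenyl instead of isoquinolin-5-yl on the sulfonyl sulfur gives a 4.1-fold higher number from compound 2 to compound 4 (0.61 log units; beyond the scatter), so the group at the far end of the molecule also counts.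

No measurement shown explains why either change moves the number. Also open, from the compounds shown here alone, is where other groups on the same aromatic carbon would fall, such as an amine, a carboxylic acid or a plain hydrogen, and whether the nitro group would give a similar number with isoquinolin-5-yl on the sulfonyl sulfur.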